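A few compounds are considered here, and "the series" means these few. Any claim that something is new, unique, unknown or untested is made for them only; others in the source may bear on it.

For the measured compounds named here, compound 3 `CCc1ccccc1-n1nncc1CN1C(=O)C2(C(C#N)=C(N)Oc3c(N)cc4nc5ccccc5nc4c32)c2ccccc21` is the one member of this set with a number in a functional assay on HepG2 cells (Homo sapiens) for antiproliferative activity, read by MTT assay, with a stated time of 48 h; on this read-out higher numbers stand for weaker inhibition and lower numbers for stronger inhibition: compound 3 gives 17900 nM. Compound 1 `N#CC1=C(N)Oc2c(c3nc4ccccc4nc3c3ccccc23)C12C(=O)N(Cc1cnnn1-c1cccc(Br)c1)c1ccccc12` reaches only a limit of the assay, > 50000 nM. Compound 2 `Cc1ccc(-n2nncc2CN2C(=O)C3(C(C#N)=C(N)Oc4c3c3nc5ccccc5nc3c3ccccc43)c3ccccc32)cc1C` likewise reaches only a limit, > 50000 nM. Going by the values given here, the sole measured step, a step that the two limits leave unreadable from compound 1 to compound 2, is therefore unreadable, as the limit of > 50000 nM in this assay, at which 2 of the 3 values shown sit, shows. Compound 4 `Cc1ccc(-n2nncc2CN2C(=O)C3(C(C#N)=C(N)Oc4c(N)cc5nc6ccccc6nc5c43)c3ccccc32)cc1C` carries the change (3,4-dimethylphenyl in place of 2-ethylphenyl on an aromatic nitrogen). Among the compounds with values here, no measured step bears on this change, and compound 2, the only compound bearing the entering group, gave no number. The account can thus expect no readable direction; compound 4 is expected to give 30000 nM (range 12000 nM to 50000 nM), a step of a 1.7-fold higher number from compound 3 to compound 4 (0.22 log units; within the scatter) that is estimated, not measured, with a fair chance that only a limit is reported.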

Compound 4, half-maximal inhibitory concentration: > 50000 nM
Compound 4: only a limit was reported (the forecaster's own chance of this, stated with the estimate: 50%); middle value at least 1.6-fold (0.22 log units) away from the limit.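

In this assay, for the compounds shown here, this is the only readable step at this place on the five-membered aromatic ring: an at least 2.7-fold higher number from compound 3 to compound 4 (0.44 log units; beyond the scatter). The leaving and entering groups have the same heavy-atom count and both are carbon only, so the way those carbons are arranged on the phenyl ring is enough to separate a measured number from a limit. The true size of the step stays unknown, as it ends at a limit: the limit of > 50000 nM in this assay, at which 3 of the 4 values shown sit.

The compounds shown leave open whether a methyl or a propyl chain in place of the ethyl chain would keep a measurable number. They also leave open whether a group such as an amine on that phenyl ring would give a lower number than compound 3.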